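The source may hold more compounds than are shown below. What is called first, only, known or untested is meant among the compounds shown, and "the series" means these compounds.

Series notes: the shared core carries a variable group on an oxygen on a saturated carbon. For the measured compounds named here, compound 1 `Cc1nn(-c2ncnc3nc[nH]c23)c2c1C(OC(=O)c1ccc(F)cc1)CC(=O)N2` bears (4-fluorophenyl)carbonyl there; in a functional assay on HEK293 cells for agonist activity at G-protein coupled receptor 39 (Homo sapiens), read by scintillation proximity assay and inositol phosphate accumulation, with a stated time of 75 min (on this read-out lower numbers stand for an effect already at smaller amounts and higher numbers for an effect only at larger amounts of compound), compound 1 gives 245 nM, the highest of the three numbers known. Compound 2 `COc1ccc(CCOC2CC(=O)Nc3c2c(C)nn3-c2ncnc3nc[nH]c23)cc1` gives 70 nM and compound 3 `Cc1nn(-c2ncnc3nc[nH]c23)c2c1C(OCc1ccccc1C#N)CC(=O)N2` gives 127 nM. Two replacements of that group have been measured: a 3.5-fold lower number from compound 1 to compound 2 (0.54 log units; beyond the scatter), while a 1.9-fold lower number from compound 1 to compound 3 (0.29 log units; within the scatter). Compound 4 `Cc1nn(-c2ncnc3nc[nH]c23)c2c1C(OCC(C)C)CC(=O)N2` carries the change (isobutyl in place of (4-fluorophenyl)carbonyl on an oxygen on a saturated carbon); isobutyl brings no ring, unlike either measured replacement. The measured steps bear on it only in that removing (4-fluorophenyl)carbonyl did not raise the number; for compound 4 a step of a 1.2-fold lower number from compound 1 to compound 4 (0.09 log units; within the scatter) is expected in this assay, not beyond the scatter. Compound 4 is estimated at 200 nM, range 60 nM to 700 nM.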

Compound 4, half-maximal effective concentration: 111 nM
For compound 4 the middle estimate is 1.8-fold (0.26 log units) above the measured one, within the range that was stated.
By their numbers in this assay, from the lowest: compounds 2, 4, 3 and 1 (each within the scatter of the next, the first and the last beyond it).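

Isobutyl in place of (4-fluorophenyl)carbonyl gives a 2.2-fold lower number from compound 1 to compound 4 (0.34 log units; beyond the scatter), so the step away from compound 1's number does not depend on a ring or a carbonyl in the group on this oxygen. Against the two replacements that carry a ring, the ringless isobutyl stays within the scatter, with a 1.1-fold lower number from compound 3 to compound 4 (0.06 log units; within the scatter) and a 1.6-fold higher number from compound 2 to compound 4 (0.20 log units; within the scatter).

From the compounds shown here alone, whether an amine, a carboxylic acid or a chain longer than isobutyl on this oxygen would hold the number at this level stays open. No measured evidence accounts for these steps.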